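Trimethoxyphenyl Swap on the Five-Membered Ring

The source may hold more compounds than are shown below. What is called first, only, known or untested is meant among the compounds shown, and "the series" means these compounds.

Compound 1 `COc1ccc(-c2cn(-c3cccc(C(=O)/C=C/c4cc(OC)c(OC)c(OC)c4)c3)c(=O)[nH]2)cc1` and compound 2 `COc1ccc(-c2cn(-c3cccc(C(=O)/C=C/c4ccc(O)c(OC)c4)c3)c(=O)[nH]2)cc1` share one core and were both tested in a functional assay on SNB-75 cells (Homo sapiens) for inhibition; on this read-out higher numbers stand for weaker inhibition of growth and lower numbers for stronger inhibition of growth. In this assay compound 1 gives 4590 nM, and compound 2 gives 4730 nM. The step of a 1.0-fold higher number from compound 1 to compound 2 (0.01 log units; within the scatter) alters only the 3,4,5-trimethoxyphenyl on a double-bonded chain carbon, and the two results cannot be told apart; compound 1 thus sits alongside compound 2 rather than apart from it.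

Among the measured compounds shown here, compound 3 `COc1cc(/C=C/C(=O)c2cccc(-n3cc(-c4cc(OC)c(OC)c(OC)c4)[nH]c3=O)c2)cc(OC)c1OC` is not yet measured. 3,4,5-trimethoxyphenyl in place of 4-methoxyphenyl on an aromatic carbon This change sits on the five-membered aromatic ring with 2 nitrogen, a spot that no measured step has touched, so nothing here speaks to its size or direction. The step of a 1.0-fold lower number from compound 1 to compound 3 (0.01 log units; within the scatter) is therefore expected to stay within the scatter, with wide uncertainty. Compound 3 is estimated at 4500 nM, between 1500 nM and 14000 nM.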

Compound 3, concentration for 50% growth inhibition: 5130 nM
For compound 3 the middle estimate is 1.1-fold (0.06 log units) below the measured one, and the stated range covers the measured number.
By their numbers in this assay, from the lowest: compounds 1, 2 and 3 (each within the scatter of the next).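

In this assay, among the compounds shown here, the step of a 1.1-fold higher number from compound 1 to compound 3 (0.05 log units; within the scatter) gives the first reading at this aromatic carbon of the five-membered aromatic ring with 2 nitrogen. It shows that 3,4,5-trimethoxyphenyl, with 12 heavy atoms, can take the place of 4-methoxyphenyl, with 8, and the two numbers still cannot be told apart. Nothing available explains this result.

On these data alone, whether any group at this aromatic carbon can move the number beyond the scatter remains open, since both groups seen here are methoxy-bearing phenyl rings. A plain phenyl, a chlorophenyl, or a group with no aromatic ring at all, such as an amine or a carboxylic acid, could show how much this position really matters for growth inhibition.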